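Same Atoms, Joined Differently: From Compound 3 to Compound 4

The compounds below may be only part of what the source reports. "The series", "measured", "known", "first", "only" and "open" are said of these compounds alone.

In a functional assay (aorta) with Rattus norvegicus as the target, in the presence of a further agent that is not named here (on this read-out lower numbers stand for an effect already at smaller amounts and higher numbers for an effect only at larger amounts of compound), three compounds sharing one core have been measured. Compound 1 `COC(=O)C1=C(C)N=C(C)/C(=C(/O)OC)C1c1ccccc1OCc1nonc1C` gives 41 nM, compound 2 `COC(=O)C1=C(C)N=C(C)/C(=C(/O)OC)C1c1ccccc1OCc1c(C)no[n+]1[O-]` gives 78 nM, and compound 3 `COC(=O)C1=C(C)N=C(C)/C(=C(/O)OC)C1c1ccccc1OCc1c(C#N)no[n+]1[O-]` gives 9.4 nM, the lowest of the three numbers. Compound 1 and compound 2 do not separate, with a 1.9-fold higher number from compound 1 to compound 2 (0.28 log units; within the scatter). Compound 3 stands apart, with a 4.4-fold lower number from compound 1 to compound 3 (0.64 log units; beyond the scatter) and an 8.3-fold lower number from compound 2 to compound 3 (0.92 log units; beyond the scatter), the latter being cyano in place of methyl on an aromatic carbon.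

Compound 4 `COC(=O)C1=C(C)N=C(C)/C(=C(/O)OC)C1c1ccccc1OCc1no[n+]([O-])c1C#N` has the same atoms as compound 3, joined differently: a group of 8 heavy atoms (3 carbon, 3 nitrogen, 2 oxygen; one five-membered aromatic ring with 3 hetero atoms) in place of a group of 8 heavy atoms (3 carbon, 3 nitrogen, 2 oxygen; one five-membered aromatic ring with 3 hetero atoms), on a saturated chain carbon bound to an oxygen on an aromatic ring. The change lies on a saturated chain carbon bound to an oxygen on an aromatic ring. Among the measured compounds shown here, none of the measured steps is of this kind. The nearest guide is an 8.3-fold lower number from compound 2 to compound 3 (0.92 log units; beyond the scatter), which shows that the number in this assay can respond to a change within this group, but that step exchanges methyl for cyano, whereas compound 4 keeps the cyano. No step beyond the scatter is therefore expected, though with little certainty. The expected step is a 1.5-fold higher number from compound 3 to compound 4 (0.17 log units; within the scatter). For compound 4 the estimate is 14 nM, with an expected range from 4 nM to 50 nM.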

Compound 4, half-maximal effective concentration: 4.4 nM
For compound 4 the middle estimate is 3.2-fold (0.50 log units) above the measured one, within the range that was stated.
By their numbers in this assay, from the lowest: compound 4; then compound 3; then compounds 1 and 2 (each within the scatter of the next).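

In this assay, among the compounds shown here, the earlier steps all changed what the group on the saturated chain carbon bound to an oxygen on an aromatic ring contains, whereas here the group keeps the same atoms and only their joining changes, and that alone gives a 2.1-fold lower number from compound 3 to compound 4 (0.33 log units; beyond the scatter). The arrangement of atoms within this group therefore counts at this position as well as its content, even though the step is modest and the counted features of the leaving and entering groups are identical. The rejoined group also widens the distance to the two compounds without cyano, with an 18-fold lower number from compound 2 to compound 4 (1.25 log units; beyond the scatter), the only large step in the series so far, and a 9.3-fold lower number from compound 1 to compound 4 (0.97 log units; beyond the scatter), leaving compound 4 with the lowest number of the four; nothing shown here gives a reason for the effect of the rejoining.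

Whether the same rejoining would move the number in a group carrying methyl in place of cyano stays open, as the compounds shown offer only one such pair, and that pair carries cyano. Also open, on these data alone, is how a carboxylic acid or a primary amide in place of the cyano, or a longer chain at the saturated chain carbon, would read in this assay.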